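The compounds below may be only part of what the source reports. "The series", "measured", "known", "first", "only" and "open" are said of these compounds alone.

Measured compounds:
- compound 1, `Cc1c(OCCCCOCOc2ccc(C(=O)O)cc2)ccc(C(=O)CC2CCCC2)c1O`: 228 nM
- compound 2, `Cc1c(OCCCCOc2cccc(C(=O)O)c2)ccc(C(=O)CC(C)C)c1C`: "not active" (no number reported)

Among the measured compounds shown here, in an assay on HEK293 cells for positive allosteric modulation of metabotropic glutamate receptor 2 (Rattus norvegicus), read by thallium flux, with a stated time of 2.5 min (on this read-out higher numbers stand for an effect only at larger amounts of compound and lower numbers for an effect already at smaller amounts), compound 1 gives 228 nM, the only number in this set. For the measured compounds named here, compound 2 is reported in this assay as "not active" (no number reported) without a number, and since it differs from compound 1 in several places at once, it shows only that not every member of this series produces a measurable effect.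

Compound 3, `Cc1c(OCCCCOc2ccc(C(=O)O)c(Cl)c2)ccc(C(=O)CC2CCCC2)c1O`, has not yet been measured. It differs from compound 1 in one place: 4-carboxy-3-chlorophenyl in place of (4-carboxyphenoxy)methyl on an oxygen on a saturated carbon. In plain terms, the spacer between the chain and the carboxylic acid-bearing ring is shortened and a chlorine is added to that ring.

Going by the values given here, no single-change step between measured compounds is available, so the size of this step cannot be read from any neighbour. The expectation for compound 3 is a step of a 1.8-fold higher number from compound 1 to compound 3 (0.24 log units; within the scatter) in this assay, that is, a modest loss that may well stay within the usual scatter. Compound 3 is therefore estimated at 400 nM, with a range from 100 nM to 2000 nM.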

Compound 3, half-maximal effective concentration: 510 nM
Compound 3: middle estimate off by 1.3-fold (0.11 log units), on the low side; low and high end bracket the measured number.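

In this assay, among the compounds shown here, putting 4-carboxy-3-chlorophenyl in place of (4-carboxyphenoxy)methyl on an oxygen on a saturated carbon gives a 2.2-fold higher number from compound 1 to compound 3 (0.35 log units; beyond the scatter), which is the first size that can be put on any change. The step is modest, so this position accepts a rather different group carrying the carboxylic acid: the effect remains measurable, but a somewhat larger amount of compound is needed to reach it. Nothing available explains why the number moves in this direction.

The two parts of this change, the altered link to the ring and the added chlorine, arrive together, so the compounds shown leave open how much of the step belongs to each; a plain 4-carboxyphenyl group without the chlorine would separate them. They also leave open whether the chlorine itself matters at all, which a fluorine or a methyl group in its place on the same ring could help to show.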